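A few compounds are considered here, and "the series" means these few. Any claim that something is new, unique, unknown or untested is made for them only; others in the source may bear on it.

Compound 1 `COc1ccc(-c2cc(C(C)=O)c3[nH]c(-c4ccccc4)cc3c2)cc1` and compound 3 `CC(=O)c1cc(/C=C/c2ccccc2)cc2cc(-c3ccccc3)[nH]c12` share a core and differ in one place: 2-phenylethenyl in place of 4-methoxyphenyl on an aromatic carbon. In a functional assay on HeLa cells (Homo sapiens) for cytotoxicity, read by MTT assay, with a stated time of 2 days, tested at 1 uM (a higher number here means a weaker effect of the compound at the concentration tested, a lower number a stronger effect), compound 1 gives 73.1%, and compound 3 gives 79.8%; the step of a number 6.7 percentage points higher from compound 1 to compound 3 (within the scatter) lies within the scatter, so the two cores behave alike here. Compound 2 `COc1ccc(-c2cc(C(C)=O)c3[nH]c(-c4ccc(F)cc4)cc3c2)cc1` differs from compound 1 by fluoro in place of hydrogen on an aromatic carbon, and in this assay compound 2 gives 56.1%, a step of a number 17 percentage points lower from compound 1 to compound 2 (beyond the scatter). Compound 4 `CC(=O)c1cc(/C=C/c2ccc(F)cc2)cc2cc(-c3ccccc3)[nH]c12` differs from compound 3 by fluoro in place of hydrogen on an aromatic carbon, the same change at the same kind of place, carried onto the other core. For the measured compounds named here, because the earlier step was a number 17 percentage points lower from compound 1 to compound 2 (beyond the scatter), a similar drop is expected, a number 15.8 percentage points lower from compound 3 to compound 4 (beyond the scatter), though with only one example the size is uncertain. Compound 4 is therefore estimated at 64%, between 50% and 80%.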

Compound 4, a percentage reported as activity, at one concentration (the size of the read-out at that concentration, not a potency): 70%
For compound 4 the middle estimate is 6 percentage points below the measured one; the measured number falls inside the stated range.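

In this assay, the step on the second core reads a number 9.8 percentage points lower from compound 3 to compound 4 (within the scatter), and it can be set beside the step on the first core: the same change on two cores in this assay, a number 17 percentage points lower (beyond the scatter) from compound 1 to compound 2 and a number 9.8 percentage points lower (within the scatter) from compound 3 to compound 4, 7.2 percentage points apart, within the scatter of two such steps. The two steps cannot be told apart, so these pairs fit the change carrying over between the cores, but the second step alone cannot be told from scatter, and one pair per core cannot fix the size of the change. Replacing the whole side group gives a number 3.1 percentage points lower from compound 1 to compound 4 (within the scatter), so this pair shows no clear difference either.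

The compounds shown leave open whether a chloro group, an amine or a carboxylic acid at the same place would behave like fluoro. They also leave open how either core responds to fluoro on its other rings.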